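Tert-butyl step repeated across two cores

The source may report more compounds than this note shows. Statements on the series, on what has been measured and on what is new or still open speak of the compounds shown alone.

The series holds two cores. Compound 1 `O=C(O)CC(NC(=O)c1ccc(Cl)cc1Cl)c1ccccc1` carries an amide, compound 2 `O=C(O)CC(NS(=O)(=O)c1ccccc1)c1ccccc1` a sulfonamide; the difference between the two cores is not broken down here. In a functional assay on MDA-MB-231 cells (Homo sapiens) for antiproliferative activity, read by MTT assay, with a stated time of 24 h (a higher number here means a weaker inhibitor, a lower number a stronger inhibitor), compound 1 gives 67200 nM. Compound 2 reaches only a limit of this assay, not a number: in this assay compound 2 gives > 100000 nM. Compound 3 `CC(C)(C)c1ccc(C(CC(=O)O)NC(=O)c2ccc(Cl)cc2Cl)cc1` is compound 1 with the change (tert-butyl in place of hydrogen on an aromatic carbon). In this assay compound 3 gives 67800 nM, and the step of a 1.0-fold higher number from compound 1 to compound 3 (0.00 log units; within the scatter) leaves the number essentially where it stood.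

Compound 4 `CC(C)(C)c1ccc(C(CC(=O)O)NS(=O)(=O)c2ccccc2)cc1` stands to compound 2 as compound 3 stands to compound 1: the change tert-butyl in place of hydrogen on an aromatic carbon is the same change, made at a place described in identical words. Among the compounds shown this change occurs twice in all, and its one measured instance is flat. The step to compound 4 is therefore expected to be about as small, a step that the limit leaves unreadable from compound 2 to compound 4, resting on a 1.0-fold higher number from compound 1 to compound 3 (0.00 log units; within the scatter). The starting point of that step is itself a limit, because compound 2 sits at the limit of > 100000 nM in this assay, at which 1 of the 3 values shown sits. Compound 4 is accordingly expected to land at 150000 nM, within a range from 60000 nM to 400000 nM, and most likely this assay will again report only a limit for compound 4 rather than a number.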

Compound 4, half-maximal inhibitory concentration: > 100000 nM
Compound 4 gave a limit, no number; the forecaster's own chance of this, stated with the estimate: 80%; the middle value is on the limit's open side.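

Compound 2 and compound 4 both give only a limit of the assay, not a number, and no step between them can be read: the limit of > 100000 nM in this assay, at which 2 of the 4 values shown sit.

Left open is whether tert-butyl in place of hydrogen on an aromatic carbon, on the core of compound 2, does anything comparable to a 1.0-fold higher number from compound 1 to compound 3 (0.00 log units; within the scatter) on the core of compound 1.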